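This account rests on a few compounds, and the source may have more. Where it says the series, first, only, none or still open, it means among the compounds named here.

The measured compounds are compound 1 `CCCCCCCCc1cn(C(c2ccccc2)c2cc3cc(Br)ccc3nc2OC)nn1` with 2.27%, compound 2 `COc1nc2ccc(Br)cc2cc1C(c1ccccc1)n1cc(CO)nn1` with 4.65%, and compound 3 `COc1nc2ccc(Br)cc2cc1C(c1ccccc1)n1cc(-c2ccc(F)cc2)nn1` with 16.4%.

In an ADME assay on PC-3 cells (Homo sapiens) for cytotoxicity, read by sulforhodamine B assay, with a stated time of 48 h, tested at 10 uM (a higher number here means more inhibition at the concentration tested (going by the name of the read-out), a lower number less inhibition), compound 3 holds the highest of the three numbers. Its nearest neighbour is separated from it by the step of a number 11.8 percentage points higher from compound 2 to compound 3 (beyond the scatter), and the furthest by the step of a number 14.1 percentage points higher from compound 1 to compound 3 (beyond the scatter); both steps lie beyond the scatter. The remaining step, a number 2.4 percentage points higher from compound 1 to compound 2 (within the scatter), concerns a different place on the core and lies within the scatter.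

Compound 4 `COc1nc2ccc(Br)cc2cc1C(c1ccccc1)n1cc(C2CC2)nn1` differs from compound 3 by cyclopropyl in place of 4-fluorophenyl on an aromatic carbon. The two steps that bear on this change are the ones that end in compound 3, since each of them placed 4-fluorophenyl on the same aromatic carbon in place of a smaller group or a chain, and each raised the number modestly. Going the other way, from 4-fluorophenyl to cyclopropyl, the expectation is therefore a modest fall, of a size that may only just clear the scatter, with a number 8.4 percentage points lower from compound 3 to compound 4 (within the scatter) as the expected step. Compound 4 is estimated at 8%, within a range from 0% to 18%.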

Compound 4, a percentage reported as inhibition, at one concentration (the size of the read-out at that concentration, not a potency): 22.6%
Estimate against measurement, compound 4: 14.6 percentage points below; the whole stated range lies below it.
By their numbers in this assay, from the lowest: compounds 1 and 2 (each within the scatter of the next); then compounds 3 and 4 (each within the scatter of the next).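

In this assay, the step to cyclopropyl on this aromatic carbon of the five-membered ring, a number 6.2 percentage points higher from compound 3 to compound 4 (within the scatter), shows that 4-fluorophenyl can give way to a non-aromatic ring of 3 heavy atoms with no change beyond the scatter, so an aromatic ring of 7 heavy atoms is not needed here to keep the number of compound 3. The steps of a number 18 percentage points higher from compound 2 to compound 4 (beyond the scatter) and a number 20.3 percentage points higher from compound 1 to compound 4 (beyond the scatter), both modest, place cyclopropyl with 4-fluorophenyl and apart from hydroxymethyl and octyl, and among these four compounds the two ring-bearing ones stand apart from the two others. Nothing available accounts for this grouping.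

The compounds shown leave open whether a cyclohexyl or an unsubstituted phenyl on this carbon would stay with compounds 3 and 4. They also leave open where an amine or a carboxylic acid would fall.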